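This account rests on a few compounds, and the source may have more. Where it says the series, first, only, none or still open, it means among the compounds named here.

Measured so far in a functional assay on A549 cells (Homo sapiens) for inhibition, read by sulforhodamine B assay (a higher number here means a weaker inhibitor of growth, a lower number a stronger inhibitor of growth), are two compounds:
- compound 1 `Cc1ccc2[nH]c(-c3ccc(-c4ccc(-c5cccc(Cl)c5)cc4)cc3)nc2c1` with 2800 nM
- compound 2 `Cc1ccc2[nH]c(-c3ccc(-c4ccc(-c5ccc(C(F)(F)F)cc5)cc4)cc3)nc2c1` with 3520 nM

Compound 2 has only compound 1 to stand against, and their two numbers lie within the scatter of each other, so neither can be ranked. Compound 3 `Cc1ccc2[nH]c(-c3ccc(-c4ccc(-c5ccc(OC(F)(F)F)cc5)cc4)cc3)nc2c1` has not been measured yet. It carries trifluoromethoxy in place of trifluoromethyl on an aromatic carbon, para to a large group (trifluoromethoxy in place of trifluoromethyl on an aromatic carbon). Among the measured compounds shown here, no measured step covers this exact swap. For the measured compounds named here, the only measured step is a 1.3-fold higher number from compound 1 to compound 2 (0.10 log units; within the scatter) and it puts 4-(trifluoromethyl)phenyl in place of 3-chlorophenyl. That step stayed within the scatter, but it is a single, different change and offers only weak guidance. With nothing pointing either way, no shift beyond the scatter is expected in this assay and no direction is favoured. The expected step is a 1.1-fold lower number from compound 2 to compound 3 (0.03 log units; within the scatter) by this estimate. In this assay the estimate for compound 3 is 3300 nM with 1500 nM to 7000 nM as the expected range.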

Compound 3, concentration for 50% growth inhibition: 3560 nM
The estimate for compound 3 lay 1.1-fold (0.03 log units) below the measured number; the range from low to high includes it.
By their numbers in this assay, from the lowest: compounds 1, 2 and 3 (each within the scatter of the next).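

In this assay, trifluoromethoxy in place of trifluoromethyl on an aromatic carbon, para to a large group, gives a 1.0-fold higher number from compound 2 to compound 3 (0.00 log units; within the scatter), so the added oxygen, counted as one hydrogen-bond acceptor, brings no difference that can be read at this position. The wider swap of 3-chlorophenyl for 4-(trifluoromethoxy)phenyl gives a 1.3-fold higher number from compound 1 to compound 3 (0.10 log units; within the scatter), so the three substituted phenyl groups now shown cannot be ranked against one another, where only one pair could be compared before. No evidence beyond these growth-inhibition numbers bears on the result.

All three compounds carry chlorine or a fluorinated group on that outer phenyl ring, which leaves open whether an amine, a carboxylic acid or a longer alkyl chain there would stay within the scatter of these three or move the number beyond it. On these data alone, whether the swap from trifluoromethyl to trifluoromethoxy would read the same on a different core in this assay also remains open.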